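The source may hold more compounds than are shown below. What is called first, only, known or untested is meant among the compounds shown, and "the series" means these compounds.

In a toxicity assay on NIH3T3 cells (Mus musculus) for cytotoxicity, read by resazurin assay (a higher number here means that more compound is needed for the effect, a lower number that less compound is needed), compound 1 `COC(=O)c1ccc(NCc2cncn2Cc2ccc(Cl)cc2)cc1-c1ccccc1` gives 25000 nM. Compound 2 `COC(=O)c1ccc(NCc2cncn2Cc2cccc(F)c2)cc1-c1ccccc1` gives > 1000 nM, which is a limit of the assay and not a number. For the measured compounds named here, the series so far therefore holds (the limit of > 1000 nM in this assay, at which 1 of the 2 values shown sits). Compound 3 `COC(=O)c1ccc(NCc2cncn2Cc2cccc(C)c2)cc1-c1ccccc1` differs from compound 2 by methyl in place of fluoro on an aromatic carbon, meta to a large group. Going by the values given here, only one measured step bears on this change, a step that the limit leaves unreadable from compound 1 to compound 2, and it offers no size to carry over. No direction can be drawn from it either. Among the compounds with values here, the only numerical anchor is compound 1 at 25000 nM. The step expected in this assay is a step that the limit leaves unreadable from compound 2 to compound 3, an estimate set against a limit. For compound 3 the estimated value is 20000 nM, with an expected range of 5000 nM to 60000 nM.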

Compound 3, half-maximal effective concentration: > 10000 nM
Compound 3 gave a limit, no number; the forecaster's own chance of this, stated with the estimate: 45%; the middle value does not contradict the limit.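

In this assay, for the compounds shown here, compound 3 gives > 10000 nM, a limit of the assay and not a number, so no step among compound 1, compound 2 and compound 3 can be read. As far as these compounds go, whether 3-fluorophenyl to 3-methylphenyl changes the value at all stays open.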